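A few compounds are considered here, and "the series" means these few. Any claim that something is new, unique, unknown or untested is made for them only; others in the source may bear on it.

Two members of the series carry numbers in a functional assay on the whole organism for inhibition, with Mythimna separata as the target, with a stated time of 5 days; a lower number here means that less compound is needed, a higher number that more compound is needed for the effect. Compound 1 `CC(C)(C)n1ncc(OCc2nnc(-c3ccc(Cl)cc3Cl)s2)c(Cl)c1=O` gives 62.2 ug/mL in this assay. For compound 2 `COc1c(F)c(F)cc(-c2nnc(COc3cnn(C(C)(C)C)c(=O)c3Cl)o2)c1F` only a limit is known: in this assay compound 2 gives > 300 ug/mL, a limit of the assay rather than a number. Compound 2 thus sits at the limit of > 300 ug/mL in this assay, at which 1 of the 2 values shown sits. For the measured compounds named here, no step between compound 1 and compound 2 is counted, as the two differ in more than one place. Compound 3 `CC(C)(C)n1ncc(OCc2nnc(-c3cc(F)c(F)cc3F)o2)c(Cl)c1=O` is not yet measured in this assay. It differs from compound 2 by hydrogen in place of methoxy on an aromatic carbon. Going by the values given here, no measured pair shows this change, so no step size can be read from the numbers given. Compound 3 is expected to give 200 ug/mL in this assay, ranging from 60 ug/mL to 600 ug/mL. The step this estimate means, an at least 1.5-fold lower number from compound 2 to compound 3 (0.17 log units; that floor lies within the scatter), is expected to stay within the usual scatter, with a fair chance that compound 3 again returns only a limit.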

Compound 3, half-maximal effective concentration: 75.7 ug/mL
Beside the measured number, compound 3's estimate is 2.6-fold (0.42 log units) above it; the range from low to high includes it.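

In this assay, hydrogen in place of methoxy on the aromatic carbon ortho to two fluoro groups gives an at least 3.9-fold lower number from compound 2 to compound 3 (0.59 log units; beyond the scatter). For the compounds shown here, this is the first change in one place that can be read, and it shows that the group on this carbon can move the read-out beyond the scatter. The value of compound 2 is a limit of the assay and not a number, so the step has only a floor and its full size stays unknown: the limit of > 300 ug/mL in this assay, at which 1 of the 3 values shown sits.

With only methoxy and hydrogen compared on this carbon, the data cannot tell whether the oxygen or the methyl carries the step, and a hydroxy or an ethoxy group there would separate the two. Going by these compounds alone, compound 1 and compound 3 differ in more than one place, so no step between them can be read.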